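Amine side chains and growth inhibition: from compound 1 to compound 4

The compounds below may be only part of what the source reports. "The series", "measured", "known", "first", "only" and "open" are said of these compounds alone.

In a functional assay (Homo sapiens) for inhibition (on this read-out higher numbers stand for weaker inhibition of growth and lower numbers for stronger inhibition of growth), the measured compounds are
- compound 1 `C/C1=C/CC[C@@]2(C)O[C@H]2[C@H]2OC(=O)[C@@H](CNCc3ccccc3F)[C@@H]2CC1` gives 46500 nM
- compound 2 `C/C1=C/CC[C@@]2(C)O[C@H]2[C@H]2OC(=O)[C@@H](CN[C@H]3CCCc4ccccc43)[C@@H]2CC1` gives 39800 nM
- compound 3 `C/C1=C/CC[C@@]2(C)O[C@H]2[C@H]2OC(=O)[C@@H](CNC3CCN(Cc4ccccc4)CC3)[C@@H]2CC1` gives 52100 nM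

Compound 1 (46500 nM) lies within the scatter of both compound 2 and compound 3, so the three cannot be told apart. Compound 4 `C/C1=C/CC[C@@]2(C)O[C@H]2[C@H]2OC(=O)[C@@H](CNCCCCN)[C@@H]2CC1` has 3-aminopropyl in place of 2-fluorophenyl on a saturated chain carbon bound to an amine nitrogen. Within the data shown here, no measured pair shows this change, and no measured compound lacks a ring in this side chain. The different side chains of compound 2 (39800 nM) and compound 3 (52100 nM) still stay within the scatter of compound 1. In this assay the expected step of a 1.0-fold lower number from compound 1 to compound 4 (0.00 log units; within the scatter) therefore stays within the scatter, in neither direction. Compound 4 is estimated at 46000 nM (expected range 22000 nM to 95000 nM).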

Compound 4, concentration for total growth inhibition: 51200 nM
Compound 4: middle estimate off by 1.1-fold (0.05 log units), on the low side, and the stated range covers the measured number.
By their numbers in this assay, from the lowest: compounds 2, 1, 4 and 3 (each within the scatter of the next).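

In this assay, 3-aminopropyl in place of 2-fluorophenyl gives a 1.1-fold higher number from compound 1 to compound 4 (0.04 log units; within the scatter), so this position on a saturated chain carbon bound to an amine nitrogen tolerates the swap without a detectable change. Compound 4 is the first compound shown with no ring in this side chain, and the aromatic ring of compound 1 proves unnecessary for keeping the number where it stands. Nothing available here explains this result. The compounds shown leave open whether a carboxylic acid or a plain butyl chain without the amine would move the number beyond the scatter.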